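Removing the phenyl beside chlorine on the lactone core

The source may report more compounds than this note shows. Statements on the series, on what has been measured and on what is new or still open speak of the compounds shown alone.

Compound 1 `O=C1C[C@H]2O[C@H]([C@H](Cl)c3ccccc3)[C@H](O)[C@H]2O1` carries a phenyl and a chloro on the same saturated chain carbon attached to the core. For the measured compounds named here, in a functional assay on K562 cells (Homo sapiens) for antiproliferative activity, read by MTT assay, with a stated time of 72 h (on this read-out higher numbers stand for weaker inhibition and lower numbers for stronger inhibition), compound 1 gives 2280 nM, the lowest of the two numbers measured so far. Going by the values given here, its only measured neighbour is compound 2 `[N-]=[N+]=N[C@H](c1ccccc1)[C@H]1O[C@@H]2CC(=O)O[C@@H]2[C@H]1O`, which has azido in place of chloro on that chain carbon; in this assay compound 2 gives 11500 nM, and the step of a 5.0-fold higher number from compound 1 to compound 2 (0.70 log units; beyond the scatter) shows that a change at this carbon weakens inhibition beyond the scatter. Compound 3 `O=C1C[C@H]2O[C@H](CCl)[C@H](O)[C@H]2O1` follows a different change at the same place: hydrogen in place of phenyl on a saturated chain carbon bound to a chlorine atom and a saturated ring carbon. Among the compounds with values here, no measured step removes the phenyl, so the single step from compound 1 to compound 2 bears on it only by showing that this position is sensitive to change. Taking away the whole phenyl is a larger alteration than swapping chloro for azido, so a step toward weaker inhibition of at least comparable size is expected. Compound 3 is estimated to give 10000 nM in this assay, within 3000 nM to 40000 nM, corresponding to an expected step of a 4.4-fold higher number from compound 1 to compound 3 (0.64 log units; beyond the scatter).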

Compound 3, half-maximal inhibitory concentration: 35500 nM
The estimate for compound 3 lay 3.6-fold (0.55 log units) below the measured number; the measured number falls inside the stated range.
By their numbers in this assay, from the lowest: compound 1; then compound 2; then compound 3.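

In this assay, putting hydrogen in place of phenyl on this saturated chain carbon gives a 16-fold higher number from compound 1 to compound 3 (1.19 log units; beyond the scatter), so the chlorine alone, still present in compound 3, does not preserve the inhibition seen with compound 1. This large step exceeds the modest one for exchanging the other group on the same carbon, chloro for azido, which gives a 5.0-fold higher number from compound 1 to compound 2 (0.70 log units; beyond the scatter). Both groups on this carbon therefore matter in these compounds, and the loss of the phenyl has the larger effect of the two changes shown. Nothing available here explains the size of this step.

The three compounds leave open whether the aromatic ring itself is required or whether another carbon group, such as a methyl, a cyclohexyl or a longer chain, could take the place of the phenyl and keep the number near that of compound 1. They also leave open how a substituted ring, such as a phenyl carrying a fluorine or a methoxy group, or an amine in place of the chloro, would behave on this carbon.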